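Swapping the amide substituent on a vitamin D receptor agonist core

This account rests on a few compounds, and the source may have more. Where it says the series, first, only, none or still open, it means among the compounds named here.

Compound 1 `CC[C@@H](C)[C@H](NC(=O)c1ccc(C(CC)(CC)c2ccc(OCC(=O)C(C)(C)C)c(C)c2)n1CC)C(=O)OC` and compound 2 `CCn1c(C(=O)N(C)CC(=O)O)ccc1C(CC)(CC)c1ccc(OCC(O)C(C)(C)C)c(C)c1` share a core and were both examined in an assay on HL-60 cells for agonist activity at vitamin D3 receptor (Homo sapiens), read by microscopy, with a stated time of 96 h; a lower number here means that less compound is needed, a higher number that more compound is needed for the effect. Compound 1 gives 590 nM, and compound 2 gives 740 nM; the two values lie within the usual scatter of each other, so neither can be called more potent on these numbers alone. Compound 3 `CCn1c(C(=O)Nc2cccc(C(F)(F)F)c2)ccc1C(CC)(CC)c1ccc(OCC(=O)C(C)(C)C)c(C)c1` has not yet been measured. It differs from compound 1 in a single place: 3-(trifluoromethyl)phenyl in place of 1-(methoxycarbonyl)-2-methylbutyl on an amide-type nitrogen. Within the data shown here, no step between two measured compounds is available for this kind of change, so the expectation rests on the two values alone. The author expects the step from compound 1 to compound 3 to be small, within or only slightly beyond the scatter, with a lean toward a lower number, and estimates a 1.5-fold lower number from compound 1 to compound 3 (0.17 log units; within the scatter). For compound 3 in this assay he estimates 400 nM, with a range from 120 nM to 1500 nM.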

Compound 3, half-maximal effective concentration: > 50000 nM
Compound 3: only a limit was reported (the forecaster's own chance of this, stated with the estimate: 10%); middle value at least 120-fold (2.09 log units) from the limit.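

Among these compounds, the amide-type nitrogen of the shared core proves to be a position where the substituent matters greatly, which the earlier values, with no step between measured compounds, could not show. In this assay, 3-(trifluoromethyl)phenyl in place of 1-(methoxycarbonyl)-2-methylbutyl gives an at least 84-fold higher number from compound 1 to compound 3 (1.92 log units; beyond the scatter). The reading for compound 3 is a limit of the assay and not a number, so this step fixes only a minimum size for the change: the limit of > 50000 nM in this assay, at which 1 of the 3 values shown sits.

As far as these compounds go, it remains open whether the loss goes with the aromatic ring itself, with the trifluoromethyl on it, or with the departure of the methyl ester and the branched chain. An unsubstituted phenyl or an isobutyl group on the same nitrogen would begin to separate these possibilities.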